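The source may report more compounds than this note shows. Statements on the series, on what has been measured and on what is new or still open speak of the compounds shown alone.

Three compounds have so far been measured in an ADME assay on Left cardiac atrium (Cavia porcellus); a higher number here means that more compound is needed for the effect, a lower number that less compound is needed:

Compound 1, `CCOC(=O)C1=C(C)NC(C)=C(C(=O)OCC)C1c1c(-c2ccc(F)c(F)c2)nc2sccn12`: 21 nM
Compound 2, `C=CCOC(=O)C1=C(C)NC(C)=C(C(=O)OCC=C)C1c1c(-c2cc(OC)c([N+](=O)[O-])cc2OC)nc2sccn12`: 25 nM
Compound 3, `CCOC(=O)C1=C(C)NC(C)=C(C(=O)OCC)C1c1c(-c2ccc(Cl)c([N+](=O)[O-])c2)nc2sc(C)cn12`: 190 nM

Compound 1 gives the lowest number of the three. Compound 2 lies so close to it that the two cannot be told apart within the usual scatter, while compound 3 sits well above both, beyond the scatter.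

Compound 4, `CCOC(=O)C1=C(C)NC(C)=C(C(=O)OCC)C1c1c(-c2ccc(Br)c([N+](=O)[O-])c2)nc2sccn12`, has not yet been measured. It differs from compound 1 in one place: 4-bromo-3-nitrophenyl in place of 3,4-difluorophenyl on an aromatic carbon. Among the measured compounds shown here, no pair of measured compounds isolates this change. Compound 3 also combines a halogen with a nitro group, but it differs from compound 1 in a second place as well, so its higher number cannot be laid to the aryl change alone.

With that reservation, the step from compound 1 to compound 4 in this assay is expected to raise the number, by an amount somewhat beyond the scatter, as a 3.3-fold higher number from compound 1 to compound 4 (0.52 log units; beyond the scatter). Compound 4 is therefore estimated at 70 nM, with a range from 20 nM to 250 nM.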

Compound 4, half-maximal effective concentration: 1270 nM
Beside the measured number, compound 4's estimate is 18-fold (1.26 log units) below it, outside the stated range (above it).
By their numbers in this assay, from the lowest: compounds 1 and 2 (each within the scatter of the next); then compound 3; then compound 4.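

In this assay, the aryl group at this position of the shared core can matter a great deal: replacing 3,4-difluorophenyl with 4-bromo-3-nitrophenyl gives a 60-fold higher number from compound 1 to compound 4 (1.78 log units; beyond the scatter). This is the only comparison shown that isolates a single change, and it makes clear that the number can climb steeply while the rest of the molecule stays fixed. No available evidence explains the size of this step.

The change replaces both fluorines with a bromine and a nitro group at once, so the compounds shown do not reveal whether one of these groups alone accounts for the rise or only the pair does. They also leave open how the number would respond if an amine or a carboxylic acid stood on this phenyl ring instead.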